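A second methyl on the benzamide of compound 3

The source may hold more compounds than are shown below. What is called first, only, known or untested is meant among the compounds shown, and "the series" means these compounds.

Measured so far:
compound 1, `COC(=O)NCC1Cc2ccc(NC(=O)c3cccc(C)c3-c3ccc(C(F)(F)F)cc3)cc2C1`: 24 nM
compound 2, `COC(=O)NCC1Cc2ccc(NC(=O)c3cc(C)cc(C)c3-c3ccc(C(F)(F)F)cc3)cc2C1`: 40 nM
compound 3, `COC(=O)NC1CCc2ccc(NC(=O)c3cccc(C)c3-c3ccc(C(F)(F)F)cc3)cc2CC1`: 20 nM

Of the compounds shown here, three have been measured in an assay on isolated protein for inhibition of microsomal triglyceride transfer protein large subunit (Homo sapiens); a higher number here means a weaker inhibitor, a lower number a stronger inhibitor. Compound 1 `COC(=O)NCC1Cc2ccc(NC(=O)c3cccc(C)c3-c3ccc(C(F)(F)F)cc3)cc2C1` gives 24 nM in this assay. Compound 2 `COC(=O)NCC1Cc2ccc(NC(=O)c3cc(C)cc(C)c3-c3ccc(C(F)(F)F)cc3)cc2C1` differs from compound 1 by methyl in place of hydrogen on an aromatic carbon; in this assay compound 2 gives 40 nM, and the step of a 1.7-fold higher number from compound 1 to compound 2 (0.22 log units; within the scatter) lies within the scatter of the measurement. Compound 3 `COC(=O)NC1CCc2ccc(NC(=O)c3cccc(C)c3-c3ccc(C(F)(F)F)cc3)cc2CC1` carries a different core from compound 1, and the difference between the two cores is not broken down here; in this assay compound 3 gives 20 nM, a number within the scatter of that of compound 1.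

Compound 4 `COC(=O)NC1CCc2ccc(NC(=O)c3cc(C)cc(C)c3-c3ccc(C(F)(F)F)cc3)cc2CC1` has not yet been measured. For the measured compounds named here, it differs from compound 3 by methyl in place of hydrogen on an aromatic carbon, which is the same change as the one from compound 1 to compound 2, made on the core of compound 3. Since the step of a 1.7-fold higher number from compound 1 to compound 2 (0.22 log units; within the scatter) was within the scatter, compound 4 is expected to stand close to compound 3, with a step of about a 1.7-fold higher number from compound 3 to compound 4 (0.23 log units; within the scatter) expected. On that basis the estimate for compound 4 in this assay is 34 nM, with a range expected from 17 nM to 70 nM. This rests on a single earlier instance of the change, from compound 1 to compound 2, and on nothing more.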

Compound 4, half-maximal inhibitory concentration: 20 nM
For compound 4 the middle estimate is 1.7-fold (0.23 log units) above the measured one; low and high end bracket the measured number.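

In this assay, a methyl in place of hydrogen on the aromatic carbon para to the 4-(trifluoromethyl)phenyl group gives no change at the digits printed from compound 3 to compound 4 (within the scatter). Set beside the earlier instance of the same change, the new step does not differ from it beyond what repeated measurement would allow: the same change on two cores in this assay, a 1.7-fold higher number (0.22 log units; within the scatter) from compound 1 to compound 2 and no change at the digits printed (within the scatter) from compound 3 to compound 4, 1.7-fold (0.22 log units) apart, within the scatter of two such steps. This shows that, on these two cores, the methyl is carried over without a step beyond the scatter on either core, and the two steps agree as far as these measurements can tell; it does not show that the change is independent of the core, since neither step is large enough to put such a transfer to a demanding test, and two pairs say nothing about any other core.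

The compounds shown leave open whether a group other than methyl at that aromatic carbon, such as an ethyl, a methoxy or a carboxylic acid, would also stay within the scatter on both cores. They also leave open how the number would respond if the methyl carbamate gave way to a urea or an amine, with or without the added methyl.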